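A few compounds are considered here, and "the series" means these few. Any claim that something is new, unique, unknown or untested is made for them only; others in the source may bear on it.

Of the compounds shown here, three built on one shared core have so far been measured in an assay on LtK cells with ATP-sensitive inward rectifier potassium channel 11 (Homo sapiens) as the target; on this read-out lower numbers stand for an effect already at smaller amounts and higher numbers for an effect only at larger amounts of compound. Compound 1 `C/C=C/C(=O)Nc1c(C(O)(C(F)(F)F)C(F)(F)F)ccc2ccccc12` gives 72 nM. Compound 2 `O=C(Nc1ccc(Cl)cc1)Nc1c(C(O)(C(F)(F)F)C(F)(F)F)ccc2ccccc12` gives 276 nM. Compound 3 `Cc1ccccc1C(=O)Nc1c(C(O)(C(F)(F)F)C(F)(F)F)ccc2ccccc12` gives 5550 nM, the highest number of the three: the step of a 77-fold higher number from compound 1 to compound 3 (1.89 log units; beyond the scatter) is large, and so is the step of a 20-fold higher number from compound 2 to compound 3 (1.30 log units; beyond the scatter), while the step of a 3.8-fold higher number from compound 1 to compound 2 (0.58 log units; beyond the scatter) is modest. Compound 4 `O=C(Nc1c(C(O)(C(F)(F)F)C(F)(F)F)ccc2ccccc12)c1ccc(Cl)c(Cl)c1` has not yet been measured. It differs from compound 3 in one place, (3,4-dichlorophenyl in place of 2-methylphenyl on a carbonyl carbon). For the measured compounds named here, no measured step changes the substitution of a phenyl ring on this carbonyl carbon, so the two large steps of a 77-fold higher number from compound 1 to compound 3 (1.89 log units; beyond the scatter) and a 20-fold higher number from compound 2 to compound 3 (1.30 log units; beyond the scatter) bear on it only indirectly: they show that the 2-methylphenyl carbonyl of compound 3 sits far above the other two groups, and compound 2, carrying a chlorine-bearing phenyl, gives 276 nM. On this basis compound 4 is expected to give a lower number than compound 3, with a step of about a 6.2-fold lower number from compound 3 to compound 4 (0.79 log units; beyond the scatter) in this assay, though the size is uncertain. The estimate for compound 4 in this assay is therefore 900 nM, with a range from 150 nM to 5000 nM.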

Compound 4, half-maximal effective concentration: 194 nM
For compound 4 the middle estimate is 4.6-fold (0.67 log units) above the measured one; the measured number falls inside the stated range.
By their numbers in this assay, from the lowest: compound 1; then compounds 4 and 2 (each within the scatter of the next); then compound 3.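

In this assay, replacing 2-methylphenyl with 3,4-dichlorophenyl on the carbonyl carbon, whose other neighbour is the amide-type nitrogen, gives a 29-fold lower number from compound 3 to compound 4 (1.46 log units; beyond the scatter), so the high number of compound 3 does not hold for every substituted phenyl at this position. The new group also matches the urea-type side chain within the scatter, at a 1.4-fold lower number from compound 2 to compound 4 (0.15 log units; within the scatter), which means that 3,4-dichlorophenyl and (4-chlorophenyl)amino cannot be told apart on this read-out. It still falls short of prop-1-en-1-yl, with a 2.7-fold higher number from compound 1 to compound 4 (0.43 log units; beyond the scatter), so the lowest number at this position stays with that group.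

Because the methyl group leaves and two chlorines enter in a single change, the compounds shown cannot separate these contributions, and a plain phenyl, a 4-chlorophenyl or a phenyl carrying an amine would be needed to do so. Nothing available here explains why this change has so large an effect.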